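Series notes: the step from compound 2 to compound 4

A few compounds are considered here, and "the series" means these few. Any claim that something is new, unique, unknown or untested is made for them only; others in the source may bear on it.

Measured so far:
compound 1 `COc1ccc(/C=C/C(=O)c2cccc(-c3cccc(F)c3)c2)cc1`: > 50000 nM
compound 2 `COc1ccc(-c2cc(C(=O)/C=C/c3cccc(OC)c3OC)ccc2N)cc1OC`: 11900 nM
compound 3 `O=C(/C=C/c1cccc(-c2ccc(F)cc2)c1)c1ccc(O)cc1`: 12400 nM

In an assay on A549 cells for inhibition of transcription factor p65 (Homo sapiens), read by fluorescence, with a stated time of 2 h (on this read-out higher numbers stand for weaker inhibition and lower numbers for stronger inhibition), compound 1 gives only a limit, > 50000 nM, not a number; this is the limit of > 50000 nM in this assay, at which 1 of the 3 values shown sits. Compound 2 gives 11900 nM in this assay, the lowest of the two numbers, and compound 3 gives 12400 nM, a value within the scatter of compound 2, so no order between these two can be read. Compound 4, `COc1ccc(/C=C/C(=O)c2ccc(N)c(-c3ccc(OC)c(OC)c3)c2)c(OC)c1`, is not yet measured. It differs from compound 2 in one place: 2,4-dimethoxyphenyl in place of 2,3-dimethoxyphenyl on a double-bonded chain carbon bound to a double-bonded chain carbon; the two have the same atoms, joined differently. Among the measured compounds shown here, no measured step of this kind exists among the three compounds. In this assay the step is expected to be small, none beyond the scatter in either direction: a 1.0-fold higher number from compound 2 to compound 4 (0.00 log units; within the scatter). Compound 4 is estimated at 12000 nM, with a range from 4000 nM to 36000 nM.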

Compound 4, half-maximal inhibitory concentration: 1700 nM
For compound 4 the middle estimate is 7.1-fold (0.85 log units) above the measured one; measured number below the stated range.
By their numbers in this assay, from the lowest: compound 4; then compounds 2 and 3 (each within the scatter of the next). At a limit, above all of these: compound 1.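

At this place, on a double-bonded chain carbon bound to a double-bonded chain carbon, 2,4-dimethoxyphenyl in place of 2,3-dimethoxyphenyl gives in this assay a 7.0-fold lower number from compound 2 to compound 4 (0.85 log units; beyond the scatter). Among the compounds shown here, the two compounds have the same atoms, so the arrangement of the two methoxy groups on this ring alone separates their values, which no earlier pair could show. Nothing measured here accounts for this step.

From the compounds shown here alone, whether 2,4-dimethoxyphenyl gives a similar step on the cores of compound 1 or compound 3 stays open. So does the effect of a dimethylamino group or a carboxylic acid in place of either methoxy group.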